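This account rests on a few compounds, and the source may have more. Where it says the series, first, only, none or still open, it means among the compounds named here.

Measured compounds:
compound 1, `C[N+]1(CCCC(=O)O)CCCC1`, 490 nM
compound 2, `CCC[N+](C)(C)CCCC(=O)[O-]`, > 1000000 nM (a limit)

In an assay for inhibition of gamma-butyrobetaine dioxygenase (Homo sapiens), read by HPLC, with stated times of 15 min and 30 min (on this read-out higher numbers stand for weaker inhibition and lower numbers for stronger inhibition), compound 1 gives 490 nM. Compound 2 is recorded only as a limit of the assay, > 1000000 nM, so it stands at the limit of > 1000000 nM in this assay, at which 1 of the 2 values shown sits, and no number is known for it. Compound 3, `C[N+](C)(CBr)CCCC(=O)[O-]`, differs from compound 2 by bromo in place of ethyl on a saturated chain carbon bound to an amine nitrogen. Among the compounds with values here, no measured step covers this change in this assay. The step is expected to run toward stronger inhibition, an at least 20-fold lower number from compound 2 to compound 3 (1.30 log units; beyond the scatter), though its size rests on a limit and is uncertain. Compound 3 is therefore estimated at 50000 nM, with a range from 2000 nM to 1000000 nM.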

Compound 3, half-maximal inhibitory concentration: > 1000000 nM
Compound 3 gave a limit, no number (the forecaster's own chance of this, stated with the estimate: 35%); at least 20-fold (1.30 log units) between middle value and limit.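

Compound 2 and compound 3 both stand only as limits, so no step can be read between them. The compounds shown leave open whether bromo in place of ethyl changes inhibition at all.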